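This account rests on a few compounds, and the source may have more. Where it says the series, first, only, none or still open, it means among the compounds named here.

Working notes on the series. Compound 1 `NCC(N)CCCNC(=O)CCn1cccc(O)c1=O` gives in a physicochemical assay, read by spectrophotometry, with a stated time of 10 min, tested at 1 mM, in the presence of a further agent that is not named here (a higher number here means a stronger effect of the compound at the concentration tested, a lower number a weaker effect), a value of 76.4%. Compound 2 `NCC(N)CCCCNC(=O)CCn1cccc(O)c1=O` gives in this assay a value of 85.6%, and compound 3 `Cc1c(O)c(=O)ccn1CCCNC(=O)CCC(N)CN` gives in this assay a value of 93.5%. Going by the values given here, the one measured step that changes a single place, a number 9.2 percentage points higher from compound 1 to compound 2 (within the scatter), concerns the saturated chain and not the ring. On the numbers shown, compound 2 stands second of three, with compound 3 and compound 1 both within the scatter of it, so no order among the three can be claimed.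

The next compound, compound 4 `NCC(N)CCCCNC(=O)CCn1cccc(OCc2ccccc2)c1=O`, differs from compound 2 by benzyl in place of hydrogen on an oxygen on an aromatic ring. Among the compounds with values here, no measured step touches this oxygen on the aromatic ring; the only step at hand, from compound 1 to compound 2, sits elsewhere and was within the scatter, so it gives no guide to the size or direction of the change here. The expectation is therefore weakly held and the range wide. The estimated step is a number 45.6 percentage points lower from compound 2 to compound 4 (beyond the scatter), and for compound 4 the expected value in this assay is 40%, within a range from 5% to 85%.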

Compound 4, a percentage reported as activity, at one concentration (the size of the read-out at that concentration, not a potency): 61.5%
Compound 4: the middle estimate sits 21.5 percentage points below what was measured; measured number inside the range.
By their numbers in this assay, from the lowest: compound 4; then compounds 1, 2 and 3 (each within the scatter of the next, the first and the last beyond it).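

Going by these compounds alone, of the steps at hand, only the one at this oxygen on an aromatic ring, hydroxy to benzyloxy, lies beyond the scatter: in this assay it reads a number 24.1 percentage points lower from compound 2 to compound 4 (beyond the scatter), whereas the change on the saturated chain, a number 9.2 percentage points higher from compound 1 to compound 2 (within the scatter), does not. The step is modest and the read-out does not vanish, as compound 4 still gives 61.5% at the single concentration tested, so a free hydroxy on this oxygen is not required for a measurable effect in this assay, although benzyl in place of hydrogen lowers the number. No measurement at hand bears on the reason for this drop.

As far as these compounds go, the series holds only hydrogen and benzyl on this oxygen, so it remains open whether a small group such as methyl would lower the number as far as benzyl does, or whether the size of the step is specific to benzyl. From the compounds shown here alone, it also remains open whether the same change gives a step of similar size on the core of compound 3, which carries a methyl group on the ring, or on the chain of compound 1.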